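From pyridin-4-yl to pyrrolidin-2-yl: working notes

The compounds below may be only part of what the source reports. "The series", "measured", "known", "first", "only" and "open" are said of these compounds alone.

- compound 1 `COc1ccc(-c2noc(-c3ccccc3)n2)cc1OC1CCCC1`: > 1000000 nM (a limit)
- compound 2 `COc1ccc(-c2noc(-c3ccncc3)n2)cc1OC1CCCC1`: > 1000000 nM (a limit)

Both entries come from a functional assay on HCT-116 cells (Homo sapiens) for antiproliferative activity, read by MTT assay, with a stated time of 24 h (a higher number here means a weaker inhibitor, a lower number a stronger inhibitor), and neither is a number. Compound 2 stands at > 1000000 nM, which is a limit of the assay. Within the data shown here, the series so far amounts to the limit of > 1000000 nM in this assay, at which 2 of the 2 values shown sit.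

Compound 3 `COc1ccc(-c2noc(C3CCCN3)n2)cc1OC1CCCC1` carries pyrrolidin-2-yl in place of pyridin-4-yl on an aromatic carbon of the shared core, a five-membered non-aromatic ring replacing a six-membered aromatic ring: pyrrolidin-2-yl in place of pyridin-4-yl on an aromatic carbon.

Among the measured compounds shown here, the only measured step bearing on this change is a step that the two limits leave unreadable from compound 1 to compound 2. It offers no size to carry over, so no step beyond the scatter and no direction can be drawn from it for this assay. The expectation therefore rests on compound 2 with its limit of > 1000000 nM, and another report of a limit is the likeliest outcome. Compound 3 is estimated at 1000000 nM, with an expected range of 200000 nM to 3000000 nM. The expected step is a number no higher from compound 2 to compound 3 (the limit leaves the size open).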

Compound 3, half-maximal inhibitory concentration: 185000 nM
Beside the measured number, compound 3's estimate is 5.4-fold (0.73 log units) above it; measured number outside the range, below it.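

Among these compounds, compound 3 is the first to give a number rather than a limit: the limit of > 1000000 nM in this assay, at which 2 of the 3 values shown sit. In this assay, this position on the five-membered aromatic ring therefore responds to the group it carries: pyrrolidin-2-yl in place of pyridin-4-yl gives an at least 5.4-fold lower number from compound 2 to compound 3 (0.73 log units; beyond the scatter), and pyrrolidin-2-yl in place of phenyl gives an at least 5.4-fold lower number from compound 1 to compound 3 (0.73 log units; beyond the scatter). Among the compounds shown here, the step between the two aromatic groups cannot be read, so the non-aromatic ring with its hydrogen-bond donor is the only change here that shows a measurable effect, and the true size of both steps remains open, since each starts from a limit.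

The change replaces a six-membered aromatic ring with a five-membered non-aromatic ring and adds a hydrogen-bond donor in a single move, so the compounds shown do not separate these features from one another. Cyclopentyl, which has no ring nitrogen, piperidin-2-yl, which has a six-membered non-aromatic ring, and an open-chain aminomethyl group would each bear on which of these features goes with the lower number.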